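This account rests on a few compounds, and the source may have more. Where it says the series, first, only, none or still open, it means among the compounds named here.

Measured compounds:
Compound 1 `Cc1csc(-c2cc(NC(=O)c3ccc(OCc4ccccn4)cc3)c(C)cc2C)n1` gives in a physicochemical assay for lipophilicity (on this read-out lower numbers stand for lower lipophilicity and higher numbers for higher lipophilicity), the assay limit > 3 and no number.
Compound 2 `Cc1cc(C)c(-c2c(C)nn(C)c2C)cc1NC(=O)c1ccc(OCc2ccccn2)cc1` gives in this assay the assay limit > 3 and no number.

Compound 2 therefore stands at the upper limit of this assay and nowhere more exactly. Going by the values given here, the only other value, that of compound 1, is the same limit, so the step that the two limits leave unreadable from compound 1 to compound 2 cannot be read; the limit of > 3 in this assay, at which 2 of the 2 values shown sit, is all the measured evidence there is, and it says only that both compounds sit at the limit.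

Compound 3 `Cc1cc(C)c(-c2ccc(N)cn2)cc1NC(=O)c1ccc(OCc2ccccn2)cc1` differs from compound 2 in one place: 5-aminopyridin-2-yl in place of 1,3,5-trimethyl-1H-pyrazol-4-yl on an aromatic carbon. Among the compounds with values here, no measured step bears on this change, since the single step available is unreadable. The direction of the step from compound 2 to compound 3 cannot be taken from the numbers shown, and the size is open as well.

The working expectation for compound 3 in this assay is 2.7, with a range from 2 to 3.3. The expected step of a number at least 0.30 log units lower from compound 2 to compound 3 (that floor lies within the scatter) is read against a limit and is correspondingly uncertain; a reading that is again only the limit remains a real possibility.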

Compound 3, distribution coefficient: 3.2
Beside the measured number, compound 3's estimate is 0.50 log units below it; the measured number falls inside the stated range.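

Compound 3 gives a number in this assay, but the steps to it from compound 1 and from compound 2 cannot be read, because those two compounds give only a limit: the limit of > 3 in this assay, at which 2 of the 3 values shown sit.

Still open, on these data alone, is how far compound 1 and compound 2 lie from compound 3, and in which direction, in this assay.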